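Swapping the thiadiazole for a pyrimidine on the sulfur

The source may report more compounds than this note shows. Statements on the series, on what has been measured and on what is new or still open speak of the compounds shown alone.

compound 1 `O=C(CSc1ncccn1)N/N=c1/scc(-c2ccc(Br)cc2)n1-c1ccccc1`: > 200 ug/mL
compound 2 `O=C(CSc1nnnn1-c1ccccc1)N/N=c1/scc(-c2ccc(Cl)cc2)n1-c1ccccc1`: > 200 ug/mL
compound 3 `Cc1nnc(SCC(=O)N/N=c2/scc(-c3ccc(Cl)cc3)n2-c2ccccc2)s1`: 28 ug/mL

In a functional assay on C6 cells (Rattus norvegicus) for cytotoxicity, read by MTT assay, with a stated time of 24 h (a lower number here means a stronger inhibitor, a higher number a weaker inhibitor), compound 1 reaches only a limit, > 200 ug/mL. Compound 2 likewise gives a limit, > 200 ug/mL. Among the measured compounds shown here, compound 3 gives 28 ug/mL, the only true number among the three. For the measured compounds named here, the one measured step, an at least 7.1-fold lower number from compound 2 to compound 3 (0.85 log units; beyond the scatter), shows that bringing in the thiadiazole group lowered the number. Compound 4 `O=C(CSc1ncccn1)N/N=c1/scc(-c2ccc(Cl)cc2)n1-c1ccccc1` reverses part of that, with pyrimidin-2-yl in place of 5-methyl-1,3,4-thiadiazol-2-yl on a sulfur. Compound 1 carries the same pyrimidin-2-yl on its sulfur and sits at the limit, as does compound 2, which is the limit of > 200 ug/mL in this assay, at which 2 of the 3 values shown sit. The expectation is therefore a rise in this assay, a 5.4-fold higher number from compound 3 to compound 4 (0.73 log units; beyond the scatter), with a fair chance that compound 4 again reports only a limit. Compound 4 is estimated at 150 ug/mL, within 40 ug/mL to 400 ug/mL.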

Compound 4, half-maximal inhibitory concentration: 83.3 ug/mL
Compound 4: middle estimate off by 1.8-fold (0.26 log units), on the high side, within the range that was stated.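

With chloro in place of bromo on an aromatic carbon, the result is an at least 2.4-fold lower number from compound 1 to compound 4 (0.38 log units; beyond the scatter) and shows that pyrimidin-2-yl on the sulfur does not by itself hold a compound at the limit. The groups on the sulfur now fall into a partial order, as a 3.0-fold higher number from compound 3 to compound 4 (0.47 log units; beyond the scatter) puts pyrimidin-2-yl behind 5-methyl-1,3,4-thiadiazol-2-yl and an at least 2.4-fold lower number from compound 2 to compound 4 (0.38 log units; beyond the scatter) puts it ahead of 1-phenyl-1H-tetrazol-5-yl in this assay readings. The two steps from limit values give only lower bounds on their size: the limit of > 200 ug/mL in this assay, at which 2 of the 4 values shown sit.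

Going by these compounds, it remains open whether the methyl or the thiadiazole ring accounts for the lower number of compound 3. On these data alone, how a morpholine or a carboxylic acid on the same chain would read also remains open.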